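From methoxy to piperidin-1-yl on a carbonyl carbon

The source may hold more compounds than are shown below. What is called first, only, known or untested is meant among the compounds shown, and "the series" means these compounds.

Measured so far in a functional assay on the whole organism (brain) with Mus musculus as the target; on this read-out lower numbers stand for an effect already at smaller amounts and higher numbers for an effect only at larger amounts of compound:
- Compound 1 `O=[N+]([O-])c1ccc(CSCc2c[nH]cn2)cc1` gives > 10 mg/kg as a limit of the assay
- Compound 2 `O=[N+]([O-])c1cccc(OCCc2c[nH]cn2)c1` gives 0.9 mg/kg as a measured number
- Compound 3 `COC(=O)c1ccc(OCCc2c[nH]cn2)cc1` gives > 3 mg/kg as a limit of the assay

Only one of these three results is an actual number, so the picture is thin. Compound 3 stands at > 3 mg/kg in this assay, which is a limit and not a number. Its true position on the dose scale is therefore not known, and any comparison with it carries that uncertainty.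

The next compound to be tested is compound 4 `O=C(c1ccc(OCCc2c[nH]cn2)cc1)N1CCCCC1`. It is made from compound 3 by one change, with piperidin-1-yl in place of methoxy on a carbonyl carbon. The entering group brings a six-membered non-aromatic ring, which the leaving group does not have.

Among the compounds with values here, no measured pair of compounds differs by a single change, so no direct precedent exists for this step. Within the data shown here, the one number available comes from compound 2 at 0.9 mg/kg in this assay, and this points to a modest expected move toward smaller doses. The expected change is an at least 2.5-fold lower number from compound 3 to compound 4 (0.39 log units; beyond the scatter) in this assay, and it remains uncertain. For compound 4 the estimated dose is 1.2 mg/kg, with an expected range from 0.3 mg/kg to 5 mg/kg in this assay.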

Compound 4, dose for half-maximal effect: > 10 mg/kg
Compound 4: only a limit was reported; the forecaster's own chance of this, stated with the estimate: 30%; middle value at least 8.3-fold (0.92 log units) from the limit.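

Within the data shown here, the results for compound 3 and compound 4 in this assay are both limits of the assay and not actual numbers, so no step between these two compounds can be read. The compounds shown leave open whether piperidin-1-yl in place of methoxy on a carbonyl carbon changes the dose needed at all, and if so, in which direction.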